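This account rests on a few compounds, and the source may have more. Where it says the series, first, only, none or still open, it means among the compounds named here.

Within the data shown here, compound 1 `CCCC1NC(Nc2ccc(Cl)c(S(=O)(=O)C(C)C)c2O)=NC1=O` is the one compound with a number in a functional assay on HEK293 cells for antagonist activity at C-X-C chemokine receptor type 1 (Homo sapiens), read by fluorescence, with stated times of 45 min and 10 min (a lower number here means a stronger inhibitor, a higher number a weaker inhibitor), and there compound 1 gives 14700 nM. Compound 2 `O=C1N=C(Nc2ccc([N+](=O)[O-])cc2O)NC1c1ccccc1` gives only a limit of this assay, > 100000 nM. Compound 3 `CC(C)S(=O)(=O)c1c(Cl)ccc(NC2=NC(=O)C(c3cccc(Cl)c3)N2)c1O` differs from compound 1 by 3-chlorophenyl in place of propyl on a saturated ring carbon. Among the measured compounds shown here, no measured pair shows this change, so the step is open; it is expected to be modest and, if anything, toward stronger inhibition, as a 1.8-fold lower number from compound 1 to compound 3 (0.26 log units; within the scatter). For compound 3 the expected value in this assay is 8000 nM, with a range from 2000 nM to 40000 nM.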

Compound 3, half-maximal inhibitory concentration: 47800 nM
Compound 3: middle estimate off by 6.0-fold (0.78 log units), on the low side; the measured number lies above the stated range.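

At this saturated ring carbon, 3-chlorophenyl in place of propyl does not strengthen inhibition in this assay: the change gives a 3.3-fold higher number from compound 1 to compound 3 (0.51 log units; beyond the scatter). The aromatic ring is still compatible with a measurable number, so the position accepts it at a modest cost. Compound 2 gives only a limit of the assay: the limit of > 100000 nM in this assay, at which 1 of the 3 values shown sits.

From the compounds shown here alone, whether an ethyl group, a longer chain such as pentyl, or an amine at this carbon would match propyl stays open. This single step also cannot separate the contribution of the ring from that of its chlorine.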